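This account rests on a few compounds, and the source may have more. Where it says the series, first, only, none or still open, it means among the compounds named here.

Three compounds share one core and differ only in the group carried on the saturated chain carbon bound to the amide-type nitrogen. In a functional assay on the whole organism (strain Wistar) for inhibition, with Rattus norvegicus as the target, read by paw edema, with stated times of 60 min and 3 h, at a dose of 100 mg/kg by the oral route (on this read-out higher numbers stand for more inhibition at the one dose given (going by the name of the read-out) and lower numbers for less inhibition), compound 1 `CNC(=O)CC1CCc2cc(OC)c(OC)cc21` gives 29%, compound 2 `CCCNC(=O)CC1CCc2cc(OC)c(OC)cc21` gives 29%, and compound 3 `CCCCNC(=O)CC1CCc2cc(OC)c(OC)cc21` gives 27.5%. The steps among them are small: no change at the digits printed from compound 1 to compound 2 (within the scatter), a number 1.5 percentage points lower from compound 1 to compound 3 (within the scatter) and a number 1.5 percentage points lower from compound 2 to compound 3 (within the scatter). Compound 3 thus holds the lowest of the three numbers, but both of the others lie within the scatter of it, so no order can be read from them.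

Compound 4 `COc1cc2c(cc1OC)C(CC(=O)NCc1ccccc1)CC2` differs from compound 3 in one place: phenyl in place of propyl on a saturated chain carbon bound to an amide-type nitrogen. For the measured compounds named here, the steps that bear on this are those that change the same position, and they were all within the scatter, as a number 1.5 percentage points lower from compound 1 to compound 3 (within the scatter) shows. Nothing measured here speaks to a ring at this position. The expectation for compound 4 is therefore no step beyond the scatter, a number 0.5 percentage points higher from compound 3 to compound 4 (within the scatter), and in this assay compound 4 is estimated at 28%, between 16% and 40%.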

Compound 4, a percentage reported as inhibition, in the whole organism at one dose (the size of the read-out at that dose, not a potency): 14.5%
For compound 4 the middle estimate is 13.5 percentage points above the measured one; the measured number lies below the stated range.
By their numbers in this assay, from the lowest: compound 4; then compounds 3, 1 and 2 (each within the scatter of the next).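

For the compounds shown here, until this result, hydrogen, ethyl and propyl on the saturated chain carbon bound to an amide-type nitrogen could not be told apart in this assay; phenyl is the first group at this position to give a step beyond the scatter, with a number 13 percentage points lower from compound 3 to compound 4 (beyond the scatter) and a number 14.5 percentage points lower from compound 2 to compound 4 (beyond the scatter) and a number 14.5 percentage points lower from compound 1 to compound 4 (beyond the scatter) as the three readings of that step. The position is therefore not indifferent to what it carries, since the one six-membered aromatic ring shown gives less inhibition at this single dose than any of the three earlier groups. Nothing available here offers an explanation for this drop.

A cyclohexyl group would show whether any ring at this position goes with the lower number or only an aromatic one. A longer chain, a pyridine ring or a phenyl ring carrying a chlorine atom or a carboxylic acid also remains open, as the compounds shown do not tell which of them would read like phenyl and which like the open chains.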